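The source may report more compounds than this note shows. Statements on the series, on what has been measured and on what is new or still open speak of the compounds shown alone.

Series notes. Compound 1 `CCOC(=O)C(=O)CC(=O)/C=C/c1cn(-c2ccccc2)c2ccccc12` and compound 2 `CCOC(=O)C(=O)CC(=O)/C=C/c1cn(Cc2ccc(C#N)cc2)c2ccccc12` share the same core and differ only at the aromatic nitrogen. In an assay on isolated protein for inhibition of DNA nucleotidylexotransferase (Homo sapiens), read by scintillation counting, with a stated time of 10 min (on this read-out higher numbers stand for weaker inhibition and lower numbers for stronger inhibition), compound 1 reaches only > 40 uM, which is a limit of the assay and not a number. Compound 2 likewise reaches only > 40 uM in this assay, again a limit and not a number. The step that the two limits leave unreadable from compound 1 to compound 2 therefore cannot be read, since both values sit at the limit of > 40 uM in this assay, at which 2 of the 2 values shown sit. Compound 2 thus stands at the limit, with no measured number behind it. Compound 3 `CCOC(=O)C(=O)CC(=O)/C=C/c1cn(CC(=O)N2CCOCC2)c2ccccc12` is the next member; the change is (morpholin-4-yl)carbonyl in place of 4-cyanophenyl on a saturated chain carbon bound to an aromatic nitrogen. Among the compounds with values here, no measured step bears on this change, and the two values shown are both limits, so no direction can be drawn from them. The expectation for compound 3 in this assay is an estimated step that the limit leaves unreadable from compound 2 to compound 3, most probably ending again at a limit. Compound 3 is estimated at 60 uM, with a range from 15 uM to 250 uM.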

Compound 3, concentration for 50% inhibition: > 40 uM
Compound 3 ended at the assay's limit; the forecaster's own chance of this, stated with the estimate: 80%; the middle value is on the limit's open side.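

No new step can be read among compound 1, compound 2 and compound 3 in this assay, since all three values are limits and not numbers: the limit of > 40 uM in this assay, at which 3 of the 3 values shown sit. The compounds shown leave open whether any group on the aromatic nitrogen of the shared core gives a measurable value.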